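The source may hold more compounds than are shown below. What is called first, only, known or untested is meant among the compounds shown, and "the series" means these compounds.

Measured compounds:
Compound 1, `OC(CCn1nc2c(Br)c(Br)c(Br)c(Br)c2n1)c1ccc(F)cc1`, gives 0% in a functional assay on CCRF-CEM cells (Homo sapiens) for antiproliferative activity, read by MTT assay, with a stated time of 48 h, tested at 100 uM; a higher number here means a weaker effect of the compound at the concentration tested, a lower number a stronger effect.
Compound 2, `COc1cccc(C(O)CCn2nc3c(Br)c(Br)c(Br)c(Br)c3n2)c1`, gives 2%.
Compound 3, `OC(CCn1nc2c(Br)c(Br)c(Br)c(Br)c2n1)c1ccccc1`, gives 0%.

On these numbers compound 2 is separated from neither neighbour: the step of a number 2 percentage points higher from compound 1 to compound 2 (within the scatter) and the step of a number 2 percentage points lower from compound 2 to compound 3 (within the scatter) both lie within the scatter, and so does no change at the digits printed from compound 1 to compound 3 (within the scatter). Compound 4, `CC(O)CCn1nc2c(Br)c(Br)c(Br)c(Br)c2n1`, has not yet been measured. It differs from compound 2 as follows: methyl in place of 3-methoxyphenyl on a saturated chain carbon bound to an oxygen on a saturated carbon and a saturated chain carbon. The two steps that touch this position are the ones already named; both were within the scatter. Among the compounds with values here, no measured step removes the whole ring in favour of a methyl, so this exchange is larger than anything measured, yet every change at this position so far left the read-out essentially at zero. The expected step is therefore none beyond the scatter, a number 1 percentage points lower from compound 2 to compound 4 (within the scatter). Compound 4 is estimated at 1%, with a range from 0% to 10%.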

Compound 4, a percentage reported as activity, at one concentration (the size of the read-out at that concentration, not a potency): 0%
Compound 4: the middle estimate sits 1 percentage points above what was measured; the range from low to high includes it.
By their numbers in this assay, from the lowest: compounds 1, 3, 4 and 2 (each within the scatter of the next).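

In this assay, within the data shown here, the change from an aromatic ring to a methyl, the largest at this position so far, gives a number 2 percentage points lower from compound 2 to compound 4 (within the scatter) and no change at the digits printed from compound 3 to compound 4 (within the scatter) and also no change at the digits printed from compound 1 to compound 4 (within the scatter). The aromatic ring, with or without its substituent, is therefore not needed for this read-out, since a single carbon in its place leaves the result within the scatter. Nothing available explains this result.

Still open, going by these compounds, is whether an amine, a carboxylic acid or a longer chain at this position would shift the read-out. On these data alone, it is also open whether the hydroxyl group matters, and a read-out at one concentration cannot separate these compounds by potency.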